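Swapping an amide for a ketone in a lipophilic chain

A few compounds are considered here, and "the series" means these few. Any claim that something is new, unique, unknown or untested is made for them only; others in the source may bear on it.

Compound 2 `CC(/C=C/CC(C)CCCC(C)C)=C\C(=O)NC(C)C` holds the lowest of the two numbers measured in a physicochemical assay for lipophilicity (a lower number here means a more polar compound, a higher number a more lipophilic compound), giving 5.65. Its nearest neighbour, compound 1 `COC(=O)/C=C(C)/C=C/CC(C)CCCC(C)C`, gives 6.2 in this assay, and the step of a number 0.55 log units lower from compound 1 to compound 2 (beyond the scatter) is the only one measured. Compound 3 `CCCC(=O)/C=C(C)/C=C/CC(C)CCCC(C)C` differs from compound 2 by propyl in place of isopropylamino on a carbonyl carbon. That change removes the isopropylamino group whose arrival brought the drop seen in a number 0.55 log units lower from compound 1 to compound 2 (beyond the scatter), so compound 3 is expected to climb in this assay by a number 0.95 log units higher from compound 2 to compound 3 (beyond the scatter), at least reversing that drop. Compound 3 is estimated at 6.6, within 6 to 7.2.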

Compound 3, partition coefficient: 6.81
Compound 3: the middle estimate sits 0.21 log units below what was measured; measured number inside the range.
By their numbers in this assay, from the lowest: compound 2; then compound 1; then compound 3.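

On this carbonyl carbon, the attached group moves the reading in this assay over a wide span: a number 1.16 log units higher from compound 2 to compound 3 (beyond the scatter) as propyl replaces isopropylamino, a change that also removes the one hydrogen-bond donor counted in that group. Propyl also surpasses methoxy, with a number 0.61 log units higher from compound 1 to compound 3 (beyond the scatter), so the order runs isopropylamino, methoxy, propyl across these three compounds. Nothing available here explains these shifts. Still open, on these data alone, is where a longer chain such as pentyl, or a carboxylic acid at this carbonyl carbon, would fall in this assay.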